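From methylsulfanyl to amino: one swap, one open number

This account rests on a few compounds, and the source may have more. Where it says the series, first, only, none or still open, it means among the compounds named here.

In a functional assay on MHCC97H cells (Homo sapiens) for antiproliferative activity, read by MTT assay, with a stated time of 48 h (on this read-out lower numbers stand for stronger inhibition and higher numbers for weaker inhibition), compound 2 (`COc1cc(C(=O)/C=C/c2cn(C)c3ccccc23)cc(SC)c1OC`) gives 150 nM and compound 1 (`COc1ccc2c(/C=C/C(=O)c3cc(N)c(OC)c(OC)c3)cn(C)c2c1`) gives 198 nM on the same read-out. Going by the values given here, these are the only two numbers so far, and they lie within the usual scatter of repeated measurements. Compound 2 therefore stands level with compound 1, and neither can be ranked over the other.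

Compound 3 (`COc1cc(C(=O)/C=C/c2cn(C)c3ccccc23)cc(N)c1OC`) is compound 2 with a single change: amino in place of methylsulfanyl on an aromatic carbon.

Among the compounds with values here, no measured pair shows this swap on its own, since compound 1 and compound 2 differ in more than one place. Still, compound 1 carries an amino group and gives 198 nM in this assay without leaving the range of compound 2. A shift beyond the scatter, in either direction, is therefore not expected. The expected step is a 1.2-fold higher number from compound 2 to compound 3 (0.08 log units; within the scatter) as an estimate only. For compound 3 the estimated value is 180 nM with an expected range from 60 nM to 550 nM in repeat measurements.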

Compound 3, half-maximal inhibitory concentration: 289 nM
The estimate for compound 3 lay 1.6-fold (0.21 log units) below the measured number; measured number inside the range.
By their numbers in this assay, from the lowest: compounds 2, 1 and 3 (each within the scatter of the next).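

Seen on its own for the first time, amino in place of methylsulfanyl, at a spot ortho to a methoxy group and meta to a large group, gives a 1.9-fold higher number from compound 2 to compound 3 (0.28 log units; within the scatter) in this assay, so this single change, which brings in a hydrogen-bond donor and removes a carbon and a sulfur, does not separate the two compounds on this read-out. The result also isolates a second change, hydrogen in place of methoxy on an aromatic carbon of the core, which gives a 1.5-fold higher number from compound 1 to compound 3 (0.16 log units; within the scatter) and so likewise leaves the two compounds level. Nothing available here explains these numbers.

The compounds shown leave open whether a different group at this spot, such as hydroxyl, dimethylamino or acetamido, would move the number beyond the scatter. From the compounds shown here alone, it also stays open whether methylsulfanyl and amino would stand as level on the core of compound 1, which keeps the extra methoxy.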